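The compounds below may be only part of what the source reports. "The series", "measured", "known", "first", "only" and "open" are said of these compounds alone.

Compound 1 `c1cncc(-c2ccccc2OCC2=NCCN2)c1` and compound 2 `c1csc(-c2ccccc2OCC2=NCCN2)c1` share one core and differ only in the aromatic ring attached to it. In a functional assay with Alpha-1A adrenergic receptor (Homo sapiens) as the target, read by calcium flux (on this read-out higher numbers stand for larger maximal responses and lower numbers for smaller maximal responses), compound 1 gives 109%, and in the same test compound 2 gives 101%. Going by the values given here, the step of a number 8 percentage points lower from compound 1 to compound 2 (within the scatter) lies within the usual scatter, so compound 2 is one of two measured compounds whose numbers cannot be told apart, and its only neighbour, compound 1, sits within the scatter of it.

Compound 3 `c1ccc(-c2ccsc2)c(OCC2=NCCN2)c1` differs from compound 2 by thiophen-3-yl in place of thiophen-2-yl on an aromatic carbon. Among the compounds with values here, no measured step matches this change, so the only guide is that the earlier swap of one small aromatic ring for another left the response unchanged. The step of a number 1 percentage points lower from compound 2 to compound 3 (within the scatter) is therefore expected to be none beyond the scatter. Compound 3 is estimated to give 100% in this assay, with a range from 85% to 115%.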

Compound 3, largest response reached (reported as maximum), in percent of the reference or control that the assay uses: 98%
Compound 3: the middle estimate sits 2 percentage points above what was measured; low and high end bracket the measured number.
By their numbers in this assay, from the lowest: compounds 3, 2 and 1 (each within the scatter of the next, the first and the last beyond it).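

Swapping thiophen-2-yl for thiophen-3-yl on this aromatic carbon moves the attachment point within the same ring and gives, in this assay, a number 3 percentage points lower from compound 2 to compound 3 (within the scatter), so no effect of that move can be read. Going by these compounds alone, replacing pyridin-3-yl with thiophen-3-yl gives a number 11 percentage points lower from compound 1 to compound 3 (beyond the scatter) and is the first step here beyond the scatter, yet the difference is modest and compound 2 lies within the scatter of both other compounds, so the three do not fall into separate groups. No available evidence explains either step.

Still open, from the compounds shown here alone, is whether pyridin-4-yl would stay within this narrow band of responses. Going by these compounds, it is also open whether a non-aromatic group at this carbon, such as an amine or a short alkyl chain, would keep the response there.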